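Adding 4-fluorobenzyl to compound 1: working notes

The source may report more compounds than this note shows. Statements on the series, on what has been measured and on what is new or still open speak of the compounds shown alone.

Measured compounds:
- compound 1 `CCN(CC)Cc1ccc(Nc2nc3ccccc3[nH]2)cc1O`: > 50000 nM
- compound 2 `CCNCc1cc(Cl)cc(Nc2nc3cc(F)c(F)cc3[nH]2)c1O`: > 50000 nM

In an ADME assay on CHO cells (Cricetulus griseus) for inhibition, read by MTT assay (a higher number here means a weaker inhibitor, a lower number a stronger inhibitor), compound 1 gives > 50000 nM, which is a limit and not a number. Compound 2 gives > 50000 nM, which is also a limit. Going by the values given here, the series so far stands at the limit of > 50000 nM in this assay, at which 2 of the 2 values shown sit. Among the compounds with values here, compound 1 therefore has no exact position on the scale, and no step between measured compounds is available to calibrate the next change.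

Compound 3 `CCN(CC)Cc1ccc(Nc2nc3ccccc3n2Cc2ccc(F)cc2)cc1O` differs from compound 1 by 4-fluorobenzyl in place of hydrogen on an aromatic nitrogen.

Compound 1 gives only the limit > 50000 nM, so the one direction open to a measurable change is toward a lower number in this assay, meaning a stronger inhibitor. A moderate step in that direction is expected, although a result again reported only as a limit remains quite possible. For compound 3 the estimate is 20000 nM, with an expected range from 6000 nM to 50000 nM. The expected change is an at least 2.5-fold lower number from compound 1 to compound 3 (0.39 log units; beyond the scatter).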

Compound 3, half-maximal inhibitory concentration: 45800 nM
Compound 3: middle estimate off by 2.3-fold (0.36 log units), on the low side; low and high end bracket the measured number.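

In this assay, going by these compounds alone, compound 3 gives 45800 nM, the first value that is a number and not a limit, so 4-fluorobenzyl in place of hydrogen on an aromatic nitrogen gives the series its first exact position on the scale. The step reads an at least 1.0-fold lower number from compound 1 to compound 3 (0.03 log units; that floor lies within the scatter), so the data do not separate this change at this position from no change at all, and they show no gain that can be claimed for the added group. The other compounds shown remain at the limit, which leaves compound 3 as the only exact point in the series: the limit of > 50000 nM in this assay, at which 2 of the 3 values shown sit.

Going by these compounds, the true size of the step stays open, as the entry for compound 1 is a limit and gives no number to measure from, so a reading beyond the scatter can neither be claimed nor ruled out. Also open, on these data alone, is whether a plain benzyl, a 4-chlorobenzyl or a short chain ending in an amine on the same aromatic nitrogen would read any differently in this assay, and so whether the fluorine matters here at all.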